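This account rests on a few compounds, and the source may have more. Where it says the series, first, only, none or still open, it means among the compounds named here.

The compounds share a single core, varied at two places. Compound 1 `O=C(Nc1ccc(Br)cc1)N[C@H]1CC[C@H](Oc2ccc(F)cc2)CC1` was tested in a functional assay on CRL2813 cells (Homo sapiens) for cytotoxicity, read by sulforhodamine B assay, with a stated time of 5 days; on this read-out higher numbers stand for weaker inhibition and lower numbers for stronger inhibition; in this assay compound 1 sits at the limit (the limit of > 20000 nM in this assay, at which 1 of the 3 values shown sits), reported as > 20000 nM. Within the data shown here, compound 2 `O=C(Nc1cccc(Cl)c1)N[C@H]1CC[C@H](Oc2ccc(F)cc2)CC1` gives 5900 nM in this assay, and the step of an at least 3.3-fold lower number from compound 1 to compound 2 (0.53 log units; beyond the scatter) is the only measured change in the set. Compound 3 `O=C(Nc1cccc(C(F)(F)F)c1)N[C@H]1CC[C@H](Oc2cccc(F)c2)CC1` gives 2400 nM in this assay, the lowest of the two numbers, the closest value being that of compound 2. Compound 4 `O=C(Nc1cccc(C(F)(F)F)c1)N[C@H]1CC[C@H](O)CC1` differs from compound 3 by hydrogen in place of 3-fluorophenyl on an oxygen on a saturated carbon. Among the measured compounds shown here, no measured step touches this part of the molecule: the one measured change concerns the group on the amide-type nitrogen, so it gives no direct guide to what happens on the oxygen on the saturated carbon. The change removes a whole aromatic ring, and the account expects a weaker result for compound 4, a higher number, by the estimated step of a 6.3-fold higher number from compound 3 to compound 4 (0.80 log units; beyond the scatter). Compound 4 is therefore estimated at 15000 nM in this assay, within a range from 5000 nM to 40000 nM, with a real chance that the result is reported only as a limit.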

Compound 4, half-maximal inhibitory concentration: > 20000 nM
Compound 4 gave a limit, no number (the forecaster's own chance of this, stated with the estimate: 40%); at least 1.3-fold (0.12 log units) between middle value and limit.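

With the trifluoromethyl-bearing aryl group on the amide-type nitrogen held constant, hydrogen in place of 3-fluorophenyl on the oxygen gives an at least 8.3-fold higher number from compound 3 to compound 4 (0.92 log units; beyond the scatter) in this assay. Among these compounds, this is the only measured step at this position, and it shows that the outcome here depends on the group on this oxygen as well as on the group on the amide-type nitrogen, the only place the earlier step had touched. Compound 4 is reported as a limit and not a number, so the step gives only a minimum size: the limit of > 20000 nM in this assay, at which 2 of the 4 values shown sit.

The compounds shown leave open whether a smaller group on this oxygen, such as methyl or a plain phenyl without fluorine, would keep the result of compound 3. They also leave open how a longer chain or an amine-bearing chain in this place would behave.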